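The compounds below may be only part of what the source reports. "The series", "measured", "known", "first", "only" and "open" are said of these compounds alone.

Series notes. The shared core, an aryl ether carrying a methylamide and an enone linker, is held constant; only the aryl group on the double-bonded chain carbon varies. Compound 1 `CNC(=O)c1cc(Oc2ccc(C(=O)/C=C/c3ccc(Cl)cc3Cl)cc2)ccn1` gives 9220 nM in a functional assay on PC-3 cells (Homo sapiens) for cytotoxicity, read by MTT assay, with a stated time of 72 h; a higher number here means a weaker inhibitor, a lower number a stronger inhibitor. Compound 2 `CNC(=O)c1cc(Oc2ccc(C(=O)/C=C/c3cccc(Br)c3)cc2)ccn1` gives 3400 nM in this assay, and compound 3 `CNC(=O)c1cc(Oc2ccc(C(=O)/C=C/c3ccccc3)cc2)ccn1` gives 3170 nM in this assay. The two moves away from compound 1 are both modest but clear: a 2.7-fold lower number from compound 1 to compound 2 (0.43 log units; beyond the scatter) and a 2.9-fold lower number from compound 1 to compound 3 (0.46 log units; beyond the scatter). Between compounds 2 and 3 the step is a 1.1-fold lower number from compound 2 to compound 3 (0.03 log units; within the scatter), within the scatter. Compound 3 therefore holds the smallest number of the three, separated from compound 1 but not from compound 2.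

Compound 4 `CNC(=O)c1cc(Oc2ccc(C(=O)/C=C/c3ccc(OC)cc3)cc2)ccn1` differs from compound 3 by methoxy in place of hydrogen on an aromatic carbon. Going by the values given here, the only measured step that changes a single substituent on this ring is the one from compound 2 to compound 3, and it was within the scatter; the larger moves from compound 1 involved two halogens at once and are less directly comparable. On this basis no step beyond the scatter is expected in this assay for a single methoxy. Compound 4 is estimated at 3000 nM, range 1400 nM to 6500 nM, an expected step of a 1.1-fold lower number from compound 3 to compound 4 (0.02 log units; within the scatter).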

Compound 4, half-maximal inhibitory concentration: > 50000 nM
Compound 4: a limit, no number; the forecaster's own chance of this, stated with the estimate: 3%; at least 16-fold (1.22 log units) between middle value and limit.
By their numbers in this assay, from the lowest: compounds 3 and 2 (each within the scatter of the next); then compound 1. At a limit, above all of these: compound 4.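

The value of compound 4 in this assay is a limit of the assay and not a number: the limit of > 50000 nM in this assay, at which 1 of the 4 values shown sits. Among the earlier compounds, the only single-substituent step on this ring stayed within the scatter, but methoxy on an aromatic carbon, para to a large group, now gives an at least 15-fold higher number from compound 3 to compound 4 (1.19 log units; beyond the scatter), so one small group on this ring can outweigh every step seen before. The wider replacements point the same way, with an at least 14-fold higher number from compound 2 to compound 4 (1.16 log units; beyond the scatter) and an at least 5.4-fold higher number from compound 1 to compound 4 (0.73 log units; beyond the scatter). The substituted ring of compound 1 still gives a measured 9220 nM, so a substituent on this ring does not in itself rule out a measured number.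

Still open, from the compounds shown here alone, is whether the jump belongs to methoxy itself or to its place on the ring, which a 3-methoxyphenyl member would help to separate. Going by these compounds, a 4-hydroxyphenyl or 4-methylphenyl member would likewise show whether the oxygen or simply any group at this place goes with the change, and the true value of compound 4 remains unknown beyond its limit.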